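A few compounds are considered here, and "the series" means these few. Any claim that something is new, unique, unknown or untested is made for them only; others in the source may bear on it.

Working notes on the series. Three members have been run in a functional assay on A549 cells (Homo sapiens) for cytotoxicity, read by WST assay, with a stated time of 72 h; a higher number here means a weaker inhibitor, a lower number a stronger inhibitor. In that assay compound 1 `COc1cc2c(Nc3nc4ccc(C(=O)Nc5c(C)cc(C)cc5C)cc4s3)ncnc2cc1OCCCN1CCC(C)CC1` gives 5400 nM, and compound 2 `COc1cc2c(Nc3nc4ccc(C(=O)Nc5c(C)cccc5Cl)cc4s3)ncnc2cc1OCCCN1CCCCC1C` gives 6700 nM. Compound 3 `COc1cc2c(Nc3nc4ccc(C(=O)Nc5c(C)cccc5C)cc4s3)ncnc2cc1OCCCN1CCCC1` gives 83800 nM in this assay, the highest of the three numbers; its gaps to compound 2 and to compound 1 both lie beyond the scatter, so compound 3 is the weakest inhibitor of the three on the numbers shown. Compound 1 and compound 2 each differ from compound 3 in more than one place, so no single change can be tied to that gap.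

The next compound, compound 4 `CCN(CC)CCCOc1cc2ncnc(Nc3nc4ccc(C(=O)Nc5c(C)cccc5C)cc4s3)c2cc1OC`, differs from compound 3 in one place only: diethylamino in place of pyrrolidin-1-yl on a saturated chain carbon, three bonds along the chain from an oxygen on an aromatic ring. No measured pair in the set isolates this kind of change, so there is no shown step to lean on. With nothing in the data pointing one way, the step is expected to be small, most likely within the scatter, with a slight lean toward a lower number given that compound 3 sits at the top of the range. The estimate for the step from compound 3 to compound 4 in this assay is therefore a 1.5-fold lower number from compound 3 to compound 4 (0.18 log units; within the scatter). On that basis compound 4 is expected to give about 55000 nM in this assay, within a range from 15000 nM to 160000 nM.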

Compound 4, half-maximal inhibitory concentration: > 100000 nM
Compound 4 gave a limit, no number; the forecaster's own chance of this, stated with the estimate: 10%; middle value at least 1.8-fold (0.25 log units) away from the limit.
By their numbers in this assay, from the lowest: compounds 1 and 2 (each within the scatter of the next); then compound 3. At a limit, above all of these: compound 4.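

Compound 4 gives > 100000 nM in this assay, which is a limit of the assay and not a number. Within the data shown here, this supplies the first step that differs in one place only: diethylamino in place of pyrrolidin-1-yl on a saturated chain carbon, three bonds along the chain from an oxygen on an aromatic ring, gives an at least 1.1-fold higher number from compound 3 to compound 4 (0.07 log units; that floor lies within the scatter). Opening the ring therefore brings no lower number in this assay, but the real size of the step cannot be read, and only its floor is known, as the value of compound 4 rests on: the limit of > 100000 nM in this assay, at which 1 of the 4 values shown sits.

From the compounds shown here alone, whether a different amine at the end of the 3-carbon chain, such as morpholin-4-yl, dimethylamino or unsubstituted piperidin-1-yl, would move the number in either direction with the rest of compound 3 kept stays open. Also open, going by these compounds, is how much of the gap between compound 3 and the lower values of compound 1 and compound 2 belongs to their methyl-substituted piperidine rings and how much to their other differences.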